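The source may hold more compounds than are shown below. What is called first, only, known or untested is meant among the compounds shown, and "the series" means these compounds.

Measured compounds:
compound 1 `COc1cc2c(cc1OC)C(CC(=O)O)CC2` — 44%
compound 2 `COc1cc2c(cc1OC)C(CC(N)=O)CC2` — 24.6%
compound 3 `COc1cc2c(cc1OC)C(CC(=O)NC1CCCCC1)CC2` — 44.7%

In a functional assay on the whole organism (strain Swiss albino) for inhibition, with Mus musculus as the target, in the writhing test, with stated times of 60 min and 15 min, at a dose of 100 mg/kg by the oral route (a higher number here means more inhibition at the dose given (going by the name of the read-out), a lower number less inhibition), compound 2 stands lowest of the three numbers: the step of a number 19.4 percentage points lower from compound 1 to compound 2 (beyond the scatter) is beyond the scatter, and so is the step of a number 20.1 percentage points higher from compound 2 to compound 3 (beyond the scatter), whereas compound 1 and compound 3 lie within the scatter of each other, as a number 0.7 percentage points higher from compound 1 to compound 3 (within the scatter) shows.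

Compound 4 `COc1cc2c(cc1OC)C(CC(=O)NCc1ccccc1)CC2` differs from compound 2 by benzyl in place of hydrogen on an amide-type nitrogen. Among the measured compounds shown here, the measured step that bears directly on this change is the one from compound 2 to compound 3, where a cyclohexyl in place of hydrogen on the amide-type nitrogen gave a number 20.1 percentage points higher from compound 2 to compound 3 (beyond the scatter), a modest rise beyond the scatter. For the measured compounds named here, no measured step has a benzyl entering at this place, so the cyclohexyl step is the only guide, and a step of about that size upward is expected, a number 17.4 percentage points higher from compound 2 to compound 4 (beyond the scatter). Compound 4 is therefore estimated at 42%, with a range from 28% to 56%.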

Compound 4, a percentage reported as inhibition, in the whole organism at one dose (the size of the read-out at that dose, not a potency): 48.1%
Estimate against measurement, compound 4: 6.1 percentage points below; measured number inside the range.
By their numbers in this assay, from the lowest: compound 2; then compounds 1, 3 and 4 (each within the scatter of the next).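

In this assay, benzyl on the amide-type nitrogen also gives a rise over the unsubstituted amide (a number 23.5 percentage points higher from compound 2 to compound 4 (beyond the scatter)), so the rise is no longer tied to cyclohexyl alone. Benzyl and cyclohexyl cannot be told apart at this place (a number 3.4 percentage points higher from compound 3 to compound 4 (within the scatter)), which means that the aromatic ring of benzyl brings no separate gain here. The benzylamino group also stays level with the hydroxy of the free acid (a number 4.1 percentage points higher from compound 1 to compound 4 (within the scatter)), leaving compound 1, compound 3 and compound 4 together, with only compound 2 beyond the scatter below them. No measured evidence explains the difference between the substituted amides and the unsubstituted amide.

From the compounds shown here alone, it remains open whether a methyl or a longer chain such as phenethyl on the same nitrogen would hold this level. Going by these compounds, the effect of dimethylamino in place of hydroxy on the carbonyl carbon, or of a chloro group on the benzyl ring, is equally open.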